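Amide-linked quinoline ethers: swapping the aryl group on the pyridine

The compounds below may be only part of what the source reports. "The series", "measured", "known", "first", "only" and "open" are said of these compounds alone.

Measured so far in a functional assay on NCI-H460 cells (Homo sapiens) for cytotoxicity, read by MTT assay, with a stated time of 72 h; a lower number here means a stronger inhibitor, a higher number a weaker inhibitor:
compound 1 `COc1ccc(-c2ccnc(C(=O)Nc3ccc(Oc4ccnc5cc(OCCCN6CCN(C)CC6)c(OC)cc45)c(F)c3)c2)c(OC)c1` 430 nM
compound 2 `COc1cc2c(Oc3ccc(NC(=O)c4cc(-c5ccc(F)cc5)ccn4)cc3F)ccnc2cc1OCCCN1CCCC1` 370 nM
compound 3 `COc1cc2c(Oc3ccc(NC(=O)c4cc(-c5ccccc5F)ccn4)cc3F)ccnc2cc1OCCCN1CCCC1` 140 nM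

Compound 3 stands lowest of the three numbers; compound 2 is nearest, compound 1 furthest, and both gaps lie beyond the scatter. Within the data shown here, the one single-point step in the set is a 2.6-fold lower number from compound 2 to compound 3 (0.42 log units; beyond the scatter), a modest move. Compound 1 and compound 2 differ in two places at once, so their values can only be read side by side: they sit close to each other.

Compound 4 `COc1ccc(-c2ccnc(C(=O)Nc3ccc(Oc4ccnc5cc(OCCCN6CCCC6)c(OC)cc45)c(F)c3)c2)c(OC)c1` is not yet measured. It differs from compound 3 by 2,4-dimethoxyphenyl in place of 2-fluorophenyl on an aromatic carbon. Among the measured compounds shown here, no measured step covers this exact change. Compound 1 carries the same 2,4-dimethoxyphenyl on a different amine chain, and its value is roughly where compound 2 lies, while compound 3 is the lowest number. A move back toward the range of compound 1 and compound 2 is therefore expected, as a 2.9-fold higher number from compound 3 to compound 4 (0.46 log units; beyond the scatter). Because compound 1 gives 430 nM, compound 4 is expected near 400 nM, with a range of 180 nM to 900 nM in this assay.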

Compound 4, half-maximal inhibitory concentration: 520 nM
The estimate for compound 4 lay 1.3-fold (0.11 log units) below the measured number, within the range that was stated.
By their numbers in this assay, from the lowest: compound 3; then compounds 2, 1 and 4 (each within the scatter of the next).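

In this assay, the site opposite the ring nitrogen accepts a second aryl swap, and a 3.7-fold higher number from compound 3 to compound 4 (0.57 log units; beyond the scatter) shows that the low number of compound 3 does not carry over to 2,4-dimethoxyphenyl. With a 1.4-fold higher number from compound 2 to compound 4 (0.15 log units; within the scatter), the 2,4-dimethoxyphenyl and 4-fluorophenyl groups cannot be told apart, so among these aryl groups only 2-fluorophenyl stands apart. The chain end can now be read in one place: a 1.2-fold higher number from compound 1 to compound 4 (0.08 log units; within the scatter) leaves pyrrolidin-1-yl and 4-methylpiperazin-1-yl indistinguishable with 2,4-dimethoxyphenyl in place, and no measurement at hand accounts for any of these steps.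

Open, going by these compounds, is whether 2-chlorophenyl or 2-methoxyphenyl at this site would match 2-fluorophenyl. Also open, on these data alone, is whether 2-fluorophenyl keeps its low number on the 4-methylpiperazin-1-yl chain.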